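A Phenyl Group Ends the Chain

The source may report more compounds than this note shows. Statements on the series, on what has been measured and on what is new or still open speak of the compounds shown alone.

In a functional assay on HCT-116 cells (Homo sapiens) for cytotoxicity, read by MTT assay, with a stated time of 48 h (on this read-out lower numbers stand for stronger inhibition and higher numbers for weaker inhibition), compound 1 `CCCCOc1ccc2c(Cl)ccnc2c1` gives 2740 nM, compound 2 `CCCCCCCCOc1ccc2c(Cl)ccnc2c1` gives 2820 nM and compound 3 `CCCCCCOc1ccc2c(Cl)ccnc2c1` gives 2440 nM. Compound 3 thus stands level with both others, within the scatter of each. Compound 4 `Clc1ccnc2cc(OCCCc3ccccc3)ccc12` differs from it by phenyl in place of propyl on a saturated chain carbon, three bonds along the chain from an oxygen on an aromatic ring. The closest measured steps, a 1.1-fold lower number from compound 1 to compound 3 (0.05 log units; within the scatter) and a 1.2-fold lower number from compound 2 to compound 3 (0.06 log units; within the scatter), change only the length of the saturated chain and stay within the scatter. None of them brings in a ring, so this evidence is indirect. The expected step is a 1.1-fold lower number from compound 3 to compound 4 (0.03 log units; within the scatter), with no change beyond the scatter foreseen. Compound 4 is estimated at 2300 nM, with an expected range from 1100 nM to 4500 nM.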

Compound 4, half-maximal inhibitory concentration: 800 nM
For compound 4 the middle estimate is 2.9-fold (0.46 log units) above the measured one; the measured number lies below the stated range.
By their numbers in this assay, from the lowest: compound 4; then compounds 3, 1 and 2 (each within the scatter of the next).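

In this assay, replacing the saturated chain end with phenyl produces a 3.1-fold lower number from compound 3 to compound 4 (0.48 log units; beyond the scatter), and the other two saturated chains give the same picture, with a 3.5-fold lower number from compound 2 to compound 4 (0.55 log units; beyond the scatter) and a 3.4-fold lower number from compound 1 to compound 4 (0.53 log units; beyond the scatter). Changing the chain length alone had left the numbers within the scatter, so this position responds to phenyl, a ring, as it did not to the added chain carbons. No available evidence accounts for this step.

The compounds shown leave open whether a cyclohexyl group would do the same as phenyl, and how an amine or a carboxylic acid at this position would fare.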